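This account rests on a few compounds, and the source may have more. Where it says the series, first, only, none or still open, it means among the compounds named here.

Measured in an ADME assay on MT4 cells (Homo sapiens) for cytotoxicity, read by MTT assay, with a stated time of 5 days; a higher number here means that more compound is tolerated, a lower number that less compound is tolerated:
- compound 1 `COc1cc2nc([S+]([O-])CC(=O)Nc3ccccc3F)nc(Nc3c(Cl)cc(/C=C/C#N)cc3Cl)c2cc1OC`: > 208000 nM (a limit)
- compound 2 `COc1cc2nc([S+]([O-])CC(=O)Nc3ccccc3C(F)(F)F)nc(Nc3c(Cl)cc(/C=C/C#N)cc3Cl)c2cc1OC`: > 192000 nM (a limit)
- compound 3 `COc1cc2nc([S+]([O-])CC(=O)Nc3ccc(C(F)(F)F)cc3)nc(Nc3c(Cl)cc(/C=C/C#N)cc3Cl)c2cc1OC`: 22000 nM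

Compound 3 is the only one of the three with a true number, and it stands lower than the two limits. Compound 4 `COc1cc2nc([S+]([O-])CC(=O)Nc3ccc(S(N)(=O)=O)cc3)nc(Nc3c(Cl)cc(/C=C/C#N)cc3Cl)c2cc1OC` carries sulfamoyl in place of trifluoromethyl on an aromatic carbon, para to a large group: sulfamoyl in place of trifluoromethyl on an aromatic carbon. The expectation for compound 4 rests on two steps, an at least 9.4-fold lower number from compound 1 to compound 3 (0.97 log units; beyond the scatter) and an at least 8.7-fold lower number from compound 2 to compound 3 (0.94 log units; beyond the scatter). Both arrive at the 4-(trifluoromethyl)phenyl group, though neither exchanges trifluoromethyl alone, so a moderate rise is expected, with wide uncertainty. In this assay the expected step is a 2.7-fold higher number from compound 3 to compound 4 (0.44 log units; beyond the scatter). For compound 4 the estimate is 60000 nM, with an expected range from 18000 nM to 200000 nM.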

Compound 4, half-maximal cytotoxic concentration: > 189000 nM
Compound 4 was reported as a limit (the forecaster's own chance of this, stated with the estimate: 35%); middle value at least 3.1-fold (0.49 log units) away from the limit.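

In this assay, exchanging this one group on the aromatic carbon, para to a large group, gives an at least 8.5-fold higher number from compound 3 to compound 4 (0.93 log units; beyond the scatter), the first step shown that changes trifluoromethyl alone, with sulfamoyl entering. Compound 4 is reported only as a limit: the limit of > 189000 nM in this assay, at which 1 of the 4 values shown sits. The steps joining compound 1 and compound 2 to compound 4 link limits and cannot be read, so the low number of compound 3 is not shared by the sulfamoyl compound. On these data alone, whether an amine or a carboxylic acid on the same carbon would also give a higher number remains open.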